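The source may hold more compounds than are shown below. What is called first, only, known or untested is meant among the compounds shown, and "the series" means these compounds.

Compound 1 (`COc1ccc2nc(C)cc(OCC(=O)Nc3ccccc3)c2c1`): in a toxicity assay on HepG2 cells (Homo sapiens) for inhibition, read by CellTiter-Glo, with a stated time of 48 h (a higher number here means a weaker inhibitor, a lower number a stronger inhibitor), compound 1 gives 39800 nM.
Compound 2 (`COc1cccc(NC(=O)COc2cc(C)nc3ccc(OC)cc23)c1`): in this assay compound 2 gives only a limit of the assay, > 100000 nM.
Compound 3 (`COc1ccc2nc(C)cc(OCC(=O)Nc3ccc(Cl)cc3)c2c1`): in this assay compound 3 likewise gives only a limit of the assay, > 100000 nM.

Compound 3 therefore stands at the ceiling of what the assay reports, as does one other value shown (the limit of > 100000 nM in this assay, at which 2 of the 3 values shown sit). Compound 4 (`COc1ccc2nc(C)cc(OCC(=O)Nc3noc(C)c3C)c2c1`) changes the group on the amide nitrogen: 4,5-dimethyl-1,2-oxazol-3-yl in place of 4-chlorophenyl on an amide-type nitrogen. For the measured compounds named here, no measured step tries this exact swap. The steps that do exist, an at least 2.5-fold higher number from compound 1 to compound 3 (0.40 log units; beyond the scatter) and an at least 2.5-fold higher number from compound 1 to compound 2 (0.40 log units; beyond the scatter), both moved from a number to a limit, and a step that the two limits leave unreadable from compound 2 to compound 3 cannot be read. With compound 3 already at a limit, the estimated step of a number no higher from compound 3 to compound 4 (the limit leaves the size open) is small, and compound 4 is expected to give about 100000 nM, somewhere between 40000 nM and 250000 nM, quite possibly again as a limit only.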

Compound 4, half-maximal inhibitory concentration: > 100000 nM
Compound 4: a limit, no number; the forecaster's own chance of this, stated with the estimate: 60%; the middle value lies on the limit itself.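

Swapping the phenyl on the amide nitrogen for 4,5-dimethyl-1,2-oxazol-3-yl gives an at least 2.5-fold higher number from compound 1 to compound 4 (0.40 log units; beyond the scatter). The move away from the plain phenyl of compound 1 in this assay therefore holds for a five-membered aromatic ring with 2 hetero atoms, not only for the substituted phenyl rings of compound 2 and compound 3. The steps among compound 2, compound 3 and compound 4 cannot be read, since all three stop at the same limit: the limit of > 100000 nM in this assay, at which 3 of the 4 values shown sit.

How far past that limit each of these compounds lies stays open. Also open, as far as these compounds go, is whether a cyclohexyl group on the amide nitrogen, or a carboxylic acid on the phenyl ring, would give a number near that of compound 1.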